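Methoxy on the shared core: notes toward compound 3

The source may report more compounds than this note shows. Statements on the series, on what has been measured and on what is new or still open speak of the compounds shown alone.

Measured so far in a functional assay on the whole organism (strain Sprague-Dawley CD) for inhibition, with Rattus norvegicus as the target, read by paw edema, at a dose of 100 mg/kg by the oral route; a higher number here means a stronger effect of the compound at the dose given, a lower number a weaker effect:
compound 1, `CCOC(=O)C(=O)Nc1cccccc1=O`, 91%
compound 2, `CCOC(=O)C(=O)Nc1ccccc(OC)c1=O`, 56%

Within the data shown here, compound 1 stands highest of the two numbers; its only neighbour is compound 2, reached by the step of a number 35 percentage points lower from compound 1 to compound 2 (beyond the scatter), a change of methoxy in place of hydrogen on an aromatic carbon. Compound 3 `CCOC(=O)C(=O)Nc1cccc(OC)cc1=O` differs from compound 1 by methoxy in place of hydrogen on an aromatic carbon. Among the measured compounds shown here, the one measured step bears directly on it: the same kind of change lowered this assay markedly. A downward step is therefore expected, of roughly that size, though with one example only its size is uncertain. Compound 3 is thus expected at 60%, within 38% to 85%. The expected step is a number 31 percentage points lower from compound 1 to compound 3 (beyond the scatter).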

Compound 3, a percentage reported as inhibition, in the whole organism at one dose (the size of the read-out at that dose, not a potency): 48%
Compound 3: the middle estimate sits 12 percentage points above what was measured, within the range that was stated.
By their numbers in this assay, from the lowest: compounds 3 and 2 (each within the scatter of the next); then compound 1.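

In this assay, methoxy on an aromatic carbon three ring bonds from the ring atom that bears the group of 8 heavy atoms also gives a large loss: a number 43 percentage points lower from compound 1 to compound 3 (beyond the scatter), a fall beyond the scatter. The loss is therefore not confined to the ring place held in compound 2. Compound 2 at 56% and compound 3 at 48% lie within the scatter of each other.

Nothing at hand accounts for the fall. As far as these compounds go, whether fluorine, a hydroxyl group or an amine at this place would keep the effect of compound 1 remains open.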